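Replacing tert-Butyl with Cyclohexyl: an Expected Step

The compounds below may be only part of what the source reports. "The series", "measured", "known", "first", "only" and "open" are said of these compounds alone.

The measured compounds in a functional assay on the whole organism with Mus musculus as the target, in the maximal electroshock model, with a stated time of 30 min; a higher number here means that more compound is needed for the effect, a lower number that less compound is needed:
compound 1 `O=C(O)c1cc[n+]([O-])cc1Oc1ccccc1` gives > 300 mg/kg, a limit of the assay.
compound 2 `CC(C)c1cc[n+]([O-])cc1Oc1ccccc1` gives 30 mg/kg.
compound 3 `CC(C)(C)c1cc[n+]([O-])cc1Oc1ccccc1` gives 30 mg/kg.

Compound 3 stands level with compound 2 at the digits shown, as no change at the digits printed from compound 2 to compound 3 (within the scatter) tells, and the only further value is the limit of compound 1 (the limit of > 300 mg/kg in this assay, at which 1 of the 3 values shown sits). From compound 1 the steps are an at least 10-fold lower number from compound 1 to compound 2 (1.00 log units; beyond the scatter) and an at least 10-fold lower number from compound 1 to compound 3 (1.00 log units; beyond the scatter), so in these three compounds an alkyl group in place of carboxy lowers the dose needed.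

Compound 4 `[O-][n+]1ccc(C2CCCCC2)c(Oc2ccccc2)c1` carries the change (cyclohexyl in place of tert-butyl on an aromatic carbon). The step that bears on it most closely is no change at the digits printed from compound 2 to compound 3 (within the scatter), where the alkyl group grew by one carbon with no change beyond the scatter. The step to compound 4 grows the alkyl group further and closes it into a ring, with no change in donors, acceptors or charge. Going by the values given here, nothing among the measured steps points to a shift in either direction, so the expected step is no change at the digits printed from compound 3 to compound 4 (within the scatter), within the scatter.

Compound 4 is therefore estimated at 30 mg/kg in this assay, with a range from 10 mg/kg to 100 mg/kg.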

Compound 4, minimum effective dose: > 300 mg/kg
Compound 4 ended at the assay's limit (the forecaster's own chance of this, stated with the estimate: 10%); at least 10-fold (1.00 log units) between middle value and limit.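

In this assay, the move from isopropyl to tert-butyl left the dose unchanged, but the position does not accept every alkyl group: cyclohexyl gives an at least 10-fold higher number from compound 3 to compound 4 (1.00 log units; beyond the scatter) and an at least 10-fold higher number from compound 2 to compound 4 (1.00 log units; beyond the scatter). The earlier pattern of an alkyl group in place of carboxy lowering the dose therefore holds for compound 2 and compound 3, and compound 4 goes against it. Compound 4 gives > 300 mg/kg, which is a limit of the assay, so the full size of both steps stays unknown, and the one step to compound 1 cannot be read, as both of its ends are limits: the limit of > 300 mg/kg in this assay, at which 2 of the 4 values shown sit.

The compounds shown do not separate the effect of the closed ring from that of the larger carbon count, and a cyclopropyl or cyclopentyl group, or an open chain such as n-hexyl, would bear on that question. They also leave open whether a ring holding an oxygen atom, such as tetrahydropyranyl, would behave like cyclohexyl at this position.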